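The source may hold more compounds than are shown below. What is called first, only, known or untested is meant among the compounds shown, and "the series" means these compounds.

Measured in an ADME assay on the whole organism (Mus musculus, strain CD1) for pharmacokinetics, at a dose of 10 mg/kg by the oral route; on this read-out higher numbers stand for higher exposure at the dose given and lower numbers for lower exposure:
- Compound 1 `CN1CCC(Oc2ccc(N3C(=S)N(c4cnc(C#N)c(C(F)(F)F)c4)C(=O)C34CCC4)cn2)CC1`: 1300 nM
- Compound 2 `Cc1cc(N2C(=O)C3(CCC3)N(c3ccc(OC4CCNCC4)nc3)C2=S)cnc1C#N`: 1880 nM
- Compound 3 `N#Cc1ncc(N2C(=O)C3(CCC3)N(c3ccc(CN4CCNCC4)cc3)C2=S)cc1C(F)(F)F`: 840 nM

Compound 2 gives 1880 nM in this assay. This number cannot be told apart from that of compound 1 (1300 nM), as the gap lies within the usual scatter of repeated measurements. Compound 3 gives 840 nM, which lies below compound 2 by more than that scatter.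

Compound 4 `N#Cc1ncc(N2C(=O)C3(CCC3)N(c3ccc(OC4CCNCC4)nc3)C2=S)cc1Cl` has not yet been measured. It differs from compound 2 in one place: chloro in place of methyl on an aromatic carbon. The 6-cyano-5-methylpyridin-3-yl of compound 2 thus becomes the 5-chloro-6-cyanopyridin-3-yl of compound 4.

Within the data shown here, no measured pair shows this swap on its own, so the data give no direct size for it. The expectation is for no change beyond the scatter, in either direction. The estimated step is a 1.2-fold lower number from compound 2 to compound 4 (0.07 log units; within the scatter), which would stay within that scatter. Compound 4 is expected at 1600 nM, with an estimated range of 700 nM to 3200 nM.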

Compound 4, maximal plasma concentration: 1880 nM
For compound 4 the middle estimate is 1.2-fold (0.07 log units) below the measured one; low and high end bracket the measured number.
By their numbers in this assay, from the lowest: compounds 3, 1, 2 and 4 (each within the scatter of the next, the first and the last beyond it).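

At this aromatic carbon, ortho to a cyano group, this assay shows no change at the digits printed from compound 2 to compound 4 (within the scatter) when chloro takes the place of methyl. Among these compounds, this is the first one-place comparison in the set, and it shows that, in this pair, the 5-chloro-6-cyanopyridin-3-yl group can stand in for the 6-cyano-5-methylpyridin-3-yl group without a change that can be told from the scatter. No accompanying measurement bears on this result.

From the compounds shown here alone, whether other groups at this carbon, such as fluoro, methoxy or an amine, would also leave the maximal plasma concentration unchanged remains open. It is also unknown whether chloro and methyl would match in the same way on compounds with a different side chain, such as compound 3.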